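The source may report more compounds than this note shows. Statements on the series, on what has been measured and on what is new or still open speak of the compounds shown alone.

Compound 2 `COc1cc(/C=C/C2CC(=O)C=CO2)cc(OC)c1OC` was measured in a functional assay on 786-0 cells (Homo sapiens) for inhibition, read by sulforhodamine B assay, with a stated time of 48 h (a lower number here means a stronger inhibitor of growth, a higher number a weaker inhibitor of growth), where compound 2 gives 125 uM. Among the three compounds measured so far, compound 2 holds the second highest number. Its nearest neighbour is compound 1 `COc1ccc(/C=C/C2CC(=O)C=CO2)cc1OC`, which in this assay gives 145 uM; the step of a 1.2-fold lower number from compound 1 to compound 2 (0.06 log units; within the scatter) keeps the two within the scatter. Furthest from it is compound 3 `COc1ccc(C2CC(=O)C(I)=CO2)cc1`, for which this assay reports 27 uM; compound 3 differs from compound 2 in more than one place, so no single step connects them, and only the two values themselves can be compared.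

Compound 4 `COc1cc(/C=C/C2CC=CC(=O)O2)cc(OC)c1OC` holds the same atoms as compound 2, joined differently: a group of 7 heavy atoms (5 carbon, 2 oxygen; one six-membered non-aromatic ring with 1 hetero atom) in place of a group of 7 heavy atoms (5 carbon, 2 oxygen; one six-membered non-aromatic ring with 1 hetero atom), on a double-bonded chain carbon bound to a double-bonded chain carbon. Within the data shown here, no measured step bears on this change. Among the measured compounds shown here, the only step available, from compound 1 to compound 2, concerns a methoxy on an aromatic carbon and stays within the scatter, so it says nothing about the rebuilt six-membered non-aromatic ring. For the measured compounds named here, the data therefore give no direction for the step, and any movement beyond the scatter would have to come from the ring rearrangement alone. Compound 4 is estimated to give 60 uM, in a range from 12 uM to 250 uM, which amounts to an expected step of a 2.1-fold lower number from compound 2 to compound 4 (0.32 log units; beyond the scatter).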

Compound 4, concentration for growth inhibition (reported as GI): 18.5 uM
Beside the measured number, compound 4's estimate is 3.2-fold (0.51 log units) above it; the measured number falls inside the stated range.
By their numbers in this assay, from the lowest: compounds 4 and 3 (each within the scatter of the next); then compounds 2 and 1 (each within the scatter of the next).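

Among these compounds, the ring change is the first single step here that moves the number in this assay beyond the scatter: a 6.8-fold lower number from compound 2 to compound 4 (0.83 log units; beyond the scatter), whereas the methoxy step, a 1.2-fold lower number from compound 1 to compound 2 (0.06 log units; within the scatter), stayed within it. The group that leaves and the group that enters match in every count printed for them, with 7 heavy atoms, 2 double bonds outside aromatic rings and 2 hydrogen-bond acceptors each, so this position on a double-bonded chain carbon responds to how the same atoms are joined, even with the composition unchanged. Nothing in the data explains why the rearranged six-membered non-aromatic ring gives the lower number.

On these data alone, the methoxy step has been read only on the ring of compound 1 and compound 2, so it remains open whether the same change would stay within the scatter on the ring of compound 4. As far as these compounds go, it is also open how compound 4, at 18.5 uM, would respond to an amine or a carboxylic acid on the aromatic ring, or to a longer chain in place of its double-bonded chain.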